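Adding a Second Methoxy Group to a Weakly Active Series

A few compounds are considered here, and "the series" means these few. Any claim that something is new, unique, unknown or untested is made for them only; others in the source may bear on it.

In a functional assay on A549 cells (Homo sapiens) for antiproliferative activity, read by MTT assay, with a stated time of 24 h (on this read-out higher numbers stand for weaker inhibition and lower numbers for stronger inhibition), compound 1 `COc1ccc(C2CC(c3ccc(Cl)cc3)=NN2c2ccc(-c3ccccc3)nn2)cc1` gives 100000 nM. Compound 2 `COc1ccc(C2CC(c3ccc(Cl)cc3)=NN2c2ccc(-c3ccccc3)nn2)c(OC)c1` reaches only the limit of this assay, > 100000 nM. The change from compound 1 to compound 2 is methoxy in place of hydrogen on an aromatic carbon, and it made a step of a number no lower from compound 1 to compound 2 (the limit leaves the size open). Compound 3 `COc1ccc(C2=NN(c3ccc(-c4ccccc4)nn3)C(c3ccc(OC)cc3)C2)cc1` also gives only the limit of this assay, > 100000 nM. Its core differs from that of compound 1 by methoxy in place of chloro on an aromatic carbon, a step of a number no lower from compound 1 to compound 3 (the limit leaves the size open). Compound 4 `COc1ccc(C2=NN(c3ccc(-c4ccccc4)nn3)C(c3ccc(OC)cc3OC)C2)cc1` has not been measured; it differs from compound 3 by methoxy in place of hydrogen on an aromatic carbon, the same change as from compound 1 to compound 2, with the same surroundings. The expected step is a number no higher from compound 3 to compound 4 (the limit leaves the size open), resting on the earlier step of a number no lower from compound 1 to compound 2 (the limit leaves the size open). Compound 4 is expected to give 100000 nM, because of the limit of > 100000 nM in this assay, at which 2 of the 3 values shown sit.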

Compound 4, half-maximal inhibitory concentration: 100000 nM
For compound 4 middle estimate and measured number coincide at the digits printed; the range from low to high includes it.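

In this assay, every step among these compounds touches a limit of the assay, so none of their sizes can be read. The added methoxy group makes a step of a number no higher from compound 3 to compound 4 (the limit leaves the size open), so it can be compared across the two cores only by direction, and that comparison does not show whether the change carries over: the same change on two cores in this assay, a number no lower (the limit leaves the size open) from compound 1 to compound 2 and a number no higher (the limit leaves the size open) from compound 3 to compound 4; the limit leaves it open whether they differ. Methoxy in place of chloro makes a step of a number no higher from compound 2 to compound 4 (the limit leaves the size open), which gives the same unresolved picture, with no evidence either for or against transfer between cores: the same change on two cores in this assay, a number no lower (the limit leaves the size open) from compound 1 to compound 3 and a number no higher (the limit leaves the size open) from compound 2 to compound 4; the limit leaves it open whether they differ.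

The compounds shown leave open how the change from 4-methoxyphenyl to 2,4-dimethoxyphenyl would behave on a core whose values stand clear of the limit. They also leave open what an amine or a carboxylic acid in place of the added methoxy would do.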